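Shortening the bromine-bearing chain of compound 3

The source may hold more compounds than are shown below. What is called first, only, known or untested is meant among the compounds shown, and "the series" means these compounds.

In a functional assay on PC-3 cells (Homo sapiens) for inhibition, read by MTT assay, with a stated time of 48 h (a lower number here means a stronger inhibitor, a higher number a weaker inhibitor), compound 1 `COc1ccc(-c2coc3cc(OCCCSC(=S)N4CCN(C)CC4)ccc3c2=O)cc1` gives 2210 nM and compound 2 `COc1ccc(-c2coc3cc(OCCCSC(=S)N4CCCC4)ccc3c2=O)cc1` gives 19400 nM while compound 3 `COc1ccc(-c2coc3cc(OCCCCBr)ccc3c2=O)cc1` gives 55600 nM as the highest number of the three, which marks it as the weakest inhibitor among them. Compound 4 `COc1ccc(-c2coc3cc(OCCBr)ccc3c2=O)cc1` is still unmeasured. It differs from compound 3 in one place, with bromo in place of 2-bromoethyl on a saturated chain carbon, two bonds along the chain from an oxygen on an aromatic ring as the counted change, which read further out is 4-bromobutoxy to 2-bromoethoxy.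

Within the data shown here, two measured steps touch this chain. The step of a 25-fold higher number from compound 1 to compound 3 (1.40 log units; beyond the scatter) is large and the step of a 2.9-fold higher number from compound 2 to compound 3 (0.46 log units; beyond the scatter) is modest, and both swap a whole ring-bearing group for a bromine-bearing one. The step of an 8.8-fold higher number from compound 1 to compound 2 (0.94 log units; beyond the scatter) only exchanges one ring for another. Among the measured compounds shown here, no measured pair changes the chain length alone, so these steps give no direction for the new change. Like compound 3 at 55600 nM compound 4 carries bromine and no ring in that chain. The step expected in this assay is therefore none beyond the scatter, estimated as a 1.1-fold lower number from compound 3 to compound 4 (0.05 log units; within the scatter) with no direction favoured. For compound 4 the estimate is 50000 nM with an expected range from 20000 nM to 120000 nM as the likely span.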

Compound 4, half-maximal inhibitory concentration: 41900 nM
The estimate for compound 4 lay 1.2-fold (0.08 log units) above the measured number; measured number inside the range.
By their numbers in this assay, from the lowest: compound 1; then compound 2; then compounds 4 and 3 (each within the scatter of the next).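

Among these compounds, this is the first pair here that differs only in chain length, and in this assay shortening 4-bromobutoxy to 2-bromoethoxy gives a 1.3-fold lower number from compound 3 to compound 4 (0.12 log units; within the scatter), so these two bromine-ended chains cannot be told apart in this assay. The shorter chain also keeps compound 4 clearly apart from the ring-bearing compounds, with a 2.2-fold higher number from compound 2 to compound 4 (0.33 log units; beyond the scatter) and a 19-fold higher number from compound 1 to compound 4 (1.28 log units; beyond the scatter), although each of these steps changes the chain and its end group together. Among these compounds, then, the large differences appear only where the end group is replaced, while this change in length alone stays within the scatter, and no supporting measurement is available to explain this result.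

The compounds shown leave open whether a longer chain, such as 6-bromohexoxy, or a chlorine atom in place of the bromine would also leave the number within the scatter. They also leave open how chain length acts when the chain ends in an amine such as morpholine, or in the 4-methylpiperazin-1-yl group of compound 1, rather than in bromine.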